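Ethynyl for trifluoromethyl on a quinazoline-urea series

This account rests on a few compounds, and the source may have more. Where it says the series, first, only, none or still open, it means among the compounds named here.

Compound 1 `C#Cc1cccc(Nc2ncnc3ccc(NC(=O)Nc4ccc(CN5CCN(C)CC5)cc4)cc23)c1`: 2810 nM
Compound 2 `O=C(Nc1ccc(CN2CCCCC2)cc1)Nc1ccc2ncnc(Nc3cccc(C(F)(F)F)c3)c2c1`: 1550 nM
Compound 3 `CCN(CC)Cc1ccc(NC(=O)Nc2ccc3ncnc(Nc4cccc(C(F)(F)F)c4)c3c2)cc1`: 3980 nM

In a functional assay on A-431 cells (Homo sapiens) for antiproliferative activity, read by MTT assay, with a stated time of 72 h (a higher number here means a weaker inhibitor, a lower number a stronger inhibitor), compound 3 gives the highest of the three numbers; compound 1 lies within the scatter of it, while compound 2 lies beyond, as a 2.6-fold higher number from compound 2 to compound 3 (0.41 log units; beyond the scatter) shows. Compound 4 `C#Cc1cccc(Nc2ncnc3ccc(NC(=O)Nc4ccc(CN(CC)CC)cc4)cc23)c1` differs from compound 3 by ethynyl in place of trifluoromethyl on an aromatic carbon. For the measured compounds named here, no measured step isolates this change. Compound 1 carries the same ethynyl group on a different amine tail, and its value sits close to that of compound 3, which gives no sign of a large shift. Compound 4 is therefore expected to stay near compound 3, with a 1.1-fold lower number from compound 3 to compound 4 (0.06 log units; within the scatter) within the scatter, at an estimated 3500 nM (range 1200 nM to 10000 nM).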

Compound 4, half-maximal inhibitory concentration: 1240 nM
For compound 4 the middle estimate is 2.8-fold (0.45 log units) above the measured one; the range from low to high includes it.
By their numbers in this assay, from the lowest: compounds 4, 2, 1 and 3 (each within the scatter of the next, the first and the last beyond it).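

In this assay, ethynyl in place of trifluoromethyl on this aromatic carbon gives a 3.2-fold lower number from compound 3 to compound 4 (0.51 log units; beyond the scatter), so with the diethylamino tail held constant, this position responds to the change beyond the scatter. With ethynyl held constant, the amine tail also matters: diethylamino in place of 4-methylpiperazin-1-yl gives a 2.3-fold lower number from compound 1 to compound 4 (0.36 log units; beyond the scatter). Nothing available explains either step.

As far as these compounds go, whether ethynyl gives a similar step on the piperidin-1-yl or 4-methylpiperazin-1-yl tails remains open. So does how a nitrile or a chlorine atom would compare at this position.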